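Hexol ester tail variants and cytotoxicity on breast cancer cells

This account rests on a few compounds, and the source may have more. Where it says the series, first, only, none or still open, it means among the compounds named here.

Measured compounds:
compound 1 `CC[C@H](C)[C@@H](O)C(=O)O[C@@H](C(=O)O[C@@H](C(=O)O[C@@H](C(=O)O[C@@H](C(=O)OC[C@@H](O)[C@@H](O)CO)[C@@H](C)CC)[C@@H](C)CC)[C@@H](C)CC)[C@@H](C)CC` — 11100 nM
compound 2 `CC[C@H](C)[C@@H](O)C(=O)O[C@@H](C(=O)O[C@@H](C(=O)O[C@@H](C(=O)O[C@@H](C(=O)O[C@@H]([C@H](O)[C@H](O)CO)[C@H](O)CO)[C@@H](C)CC)[C@@H](C)CC)[C@@H](C)CC)[C@@H](C)CC` — 27800 nM
compound 3 `CC[C@H](C)[C@@H](O)C(=O)O[C@@H](C(=O)O[C@@H](C(=O)O[C@@H](C(=O)O[C@@H](C(=O)O[C@H](CO)[C@@H](O)[C@H](O)[C@H](O)CO)[C@@H](C)CC)[C@@H](C)CC)[C@@H](C)CC)[C@@H](C)CC` — 18300 nM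

In a functional assay on MCF7 cells (Homo sapiens) for cytotoxicity, read by MTT assay, with a stated time of 24 h (a higher number here means a weaker inhibitor, a lower number a stronger inhibitor), compound 2 gives the highest number of the three; compound 3 sits within the scatter of it, while compound 1 lies beyond it, a step of a 2.5-fold higher number from compound 1 to compound 2 (0.40 log units; beyond the scatter). The step of a 1.5-fold lower number from compound 2 to compound 3 (0.18 log units; within the scatter) is within the scatter.

Compound 4 `CC[C@H](C)[C@@H](O)C(=O)O[C@@H](C(=O)O[C@@H](C(=O)O[C@@H](C(=O)O[C@@H](C(=O)OC[C@@H](O)[C@@H](O)[C@H](O)[C@H](O)CO)[C@@H](C)CC)[C@@H](C)CC)[C@@H](C)CC)[C@@H](C)CC` differs from compound 2 by 2,3,4,5,6-pentahydroxyhexyl in place of 1-(1,2-dihydroxyethyl)-2,3,4-trihydroxybutyl on an oxygen next to a carbonyl group. The bearing step is a 2.5-fold higher number from compound 1 to compound 2 (0.40 log units; beyond the scatter), where the change to a branched attachment raised the number; compound 4 returns to an unbranched attachment, so a modest lower number is expected, while a 1.5-fold lower number from compound 2 to compound 3 (0.18 log units; within the scatter) warns that the effect may stay within the scatter. Compound 4 is therefore estimated at 14000 nM (range 7000 nM to 30000 nM), meaning an expected step of a 2.0-fold lower number from compound 2 to compound 4 (0.30 log units; within the scatter).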

Compound 4, half-maximal inhibitory concentration: 24300 nM
Compound 4: middle estimate off by 1.7-fold (0.24 log units), on the low side, and the stated range covers the measured number.
By their numbers in this assay, from the lowest: compounds 1, 3, 4 and 2 (each within the scatter of the next, the first and the last beyond it).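

In this assay, the unbranched 2,3,4,5,6-pentahydroxyhexyl on this oxygen cannot be told apart from either branched group of the same size (a 1.1-fold lower number from compound 2 to compound 4 (0.06 log units; within the scatter)) (a 1.3-fold higher number from compound 3 to compound 4 (0.12 log units; within the scatter)), so branching at the attachment carbon shows no readable effect. Adding 1,2-dihydroxyethyl in place of hydrogen on the compound 1 chain gives a step beyond the scatter (a 2.2-fold higher number from compound 1 to compound 4 (0.34 log units; beyond the scatter)), although compound 3, within the scatter of compound 1, goes against any simple link with chain size. No evidence is available to explain these steps.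

Open, from the compounds shown here alone, is whether an amine or a carboxylic acid on this chain would move the number beyond the scatter of compound 4.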